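A few compounds are considered here, and "the series" means these few. Any claim that something is new, unique, unknown or untested is made for them only; others in the source may bear on it.

Measured so far in an assay on isolated protein for inhibition of P-selectin glycoprotein ligand 1 (Homo sapiens), read by surface plasmon resonance, tested at 250 uM; on this read-out lower numbers stand for less inhibition and higher numbers for more inhibition at the one concentration tested (going by the name of the read-out):

- compound 1, `Cc1cc(C)c2nc(C3(c4ccc(Cl)cc4)CC3)c(O)c(C(=O)O)c2c1`, gives 47%
- compound 2, `O=C(O)c1c(O)c(C2(c3cccs3)CC2)nc2c(C(F)(F)F)cccc12`, gives 15%

Compound 1 holds the higher of the two numbers in this assay. Going by the values given here, compound 2, the only other measured compound, is the nearest point and stands lower by a margin that lies beyond the usual scatter; compound 2 differs from compound 1 at more than one place, so the gap between them cannot be tied to any single change.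

The next compound, compound 3, `Cc1cc(C)c2nc(C3(c4ccc(F)cc4)CC3)c(O)c(C(=O)O)c2c1`, keeps the core of compound 1 and differs from it only at one point: fluoro in place of chloro on an aromatic carbon. Among the compounds with values here, no measured pair isolates this exchange, so there is no recorded step to lean on. Exchanging one halogen for another at the same aromatic carbon is a small change by the count shown, and the expectation is a small downward step from compound 1 to compound 3, a number 9 percentage points lower from compound 1 to compound 3 (within the scatter), most likely within the scatter rather than beyond it. In this assay compound 3 is accordingly estimated at 38%, with a range from 20% to 55%.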

Compound 3, a percentage reported as inhibition, at one concentration (the size of the read-out at that concentration, not a potency): <= 10%
Compound 3: only a limit was reported; the forecaster's own chance of this, stated with the estimate: 0%; middle value at least 28 percentage points from the limit.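

In this assay this para position turns out to be sensitive: fluoro in place of chloro on the aromatic carbon, the change from 4-chlorophenyl to 4-fluorophenyl, gives a number at least 37 percentage points lower from compound 1 to compound 3 (beyond the scatter). Going by these compounds alone, this is the first step that isolates a single place, and it shows that swapping one halogen for another, with one heavy atom leaving, one entering and no change in the count of hydrogen-bond donors, acceptors or net charge, is enough to produce a large loss in the read-out. The value for compound 3 is a limit, so the step fixes only the least size of the drop and not its full size: the limit of <= 10% in this assay, at which 1 of the 3 values shown sits.

On these data alone, what remains open is whether the chloro of compound 1 can be matched or improved on at this carbon by bromo, methyl, methoxy or an unsubstituted phenyl ring, which would show whether the response runs beyond the two halogens. Also open, as far as these compounds go, is whether the same exchange carries the same penalty when the other parts of the shared core are changed, for instance with trifluoromethyl on the core in place of the two methyl groups.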